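Tolerance limits in a three-member series and one new analogue

A few compounds are considered here, and "the series" means these few. Any claim that something is new, unique, unknown or untested is made for them only; others in the source may bear on it.

Compound 1 `CCCOc1ccc(CN(Cc2ccc(C(C)(C)C)cc2)Cc2cc3cc(C)ccc3[nH]c2=O)cc1` and compound 2 `CCCCOc1ccc(CN(Cc2ccc(C(C)(C)C)cc2)Cc2cc3cc(C)ccc3[nH]c2=O)cc1` share a core; compound 3 `COc1ccc(C(C)N(Cc2ccc(C(C)(C)C)cc2)Cc2cc3cc(C)ccc3[nH]c2=O)cc1Cl` differs from compound 1 by 1-(3-chloro-4-methoxyphenyl)ethyl in place of 4-propoxybenzyl on an amine nitrogen. In a toxicity assay on MDCK cells (Canis lupus familiaris) for cytotoxicity, read by crystal violet staining, with a stated time of 48 h (a higher number here means that more compound is tolerated, a lower number that less compound is tolerated), compound 1 gives only a limit, > 5000 nM. Compound 2 likewise reaches only a limit in this assay, > 5000 nM. Compound 3 also stops at a limit in this assay, > 10000 nM. The change from compound 1 to compound 2 is methyl in place of hydrogen on a saturated chain carbon, three bonds along the chain from an oxygen on an aromatic ring, and its step that the two limits leave unreadable from compound 1 to compound 2 cannot be read; nor can a step that the two limits leave unreadable from compound 1 to compound 3 or a step that the two limits leave unreadable from compound 2 to compound 3. The steps stay unreadable because the limit of > 5000 nM in this assay, at which 2 of the 3 values shown sit, holds two of the values and the limit of > 10000 nM in this assay, at which 1 of the 3 values shown sits, the third.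

Compound 4 `CCc1ccc2[nH]c(=O)c(CN(Cc3ccc(C(C)(C)C)cc3)C(C)c3ccc(OC)c(Cl)c3)cc2c1` is not yet measured and differs from compound 3 by methyl in place of hydrogen on a saturated chain carbon bound to an aromatic carbon. This is the same kind of change as from compound 1 to compound 2, though the place differs: there on a saturated chain carbon, three bonds along the chain from an oxygen on an aromatic ring, here on a saturated chain carbon bound to an aromatic carbon. The step that the limit leaves unreadable from compound 3 to compound 4 is an expectation, resting on compound 3 sitting at the limit > 10000 nM and on the unreadable a step that the two limits leave unreadable from compound 1 to compound 2. Compound 4 is therefore expected near 15000 nM, between 5000 nM and 50000 nM, most likely reported again only as a limit in this assay.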

Compound 4, half-maximal cytotoxic concentration: > 10000 nM
Compound 4: no number, only a limit; the forecaster's own chance of this, stated with the estimate: 80%; the middle value lies beyond the limit too.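

In this assay compound 4 gives only a limit of > 10000 nM and so no new step can be read against compound 3, which also stands at a limit. The compounds shown leave open at what concentration any of the four reaches half-maximal cytotoxicity, and so whether methyl in place of hydrogen alters tolerance in this assay at all.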